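Swapping an Ethyl for 4-Chlorophenoxy on a Triazole Benzhydryl

A few compounds are considered here, and "the series" means these few. Any claim that something is new, unique, unknown or untested is made for them only; others in the source may bear on it.

Measured so far:
compound 1, `N#Cc1ccc(C(c2ccc(C#N)cc2)n2cc(COc3ccc([N+](=O)[O-])cc3)nn2)cc1`, 7730 nM
compound 2, `CCCc1cn(C(c2ccccc2)c2ccccc2)nn1`, 11000 nM

Both compounds were tested in an assay on isolated protein for inhibition of Aromatase (Homo sapiens), read by fluorescence and colorimetric assay, with a stated time of 30 min; on this read-out lower numbers stand for stronger inhibition and higher numbers for weaker inhibition. Compound 1 gives 7730 nM. Compound 2 gives 11000 nM. Compound 2 has the highest of the two numbers, but its gap to compound 1 lies within the scatter, so the two cannot be told apart on this evidence.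

Compound 3, `Clc1ccc(OCc2cn(C(c3ccccc3)c3ccccc3)nn2)cc1`, has not yet been measured. It differs from compound 2 in one place: 4-chlorophenoxy in place of ethyl on a saturated chain carbon bound to an aromatic carbon. In other words, the propyl chain on the core of compound 2 becomes a (4-chlorophenoxy)methyl chain in compound 3. A comparable arm, ending in an aromatic ring carrying a nitro group, is found in compound 1, whose number sits close to that of compound 2.

Among the compounds with values here, no step between measured compounds is available to anchor this change, so only a small step is expected, if any beyond the scatter, and its direction is uncertain; the estimated step of a 1.8-fold lower number from compound 2 to compound 3 (0.26 log units; within the scatter) leans slightly toward a lower number. Compound 3 is expected to give 6000 nM, with a range from 2000 nM to 20000 nM.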

Compound 3, half-maximal inhibitory concentration: 13400 nM
Beside the measured number, compound 3's estimate is 2.2-fold (0.35 log units) below it; the range from low to high includes it.
By their numbers in this assay, from the lowest: compounds 1, 2 and 3 (each within the scatter of the next).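

In this assay, putting 4-chlorophenoxy in place of ethyl on a saturated chain carbon bound to an aromatic carbon gives a 1.2-fold higher number from compound 2 to compound 3 (0.09 log units; within the scatter). Within the data shown here, this is the first direct comparison at this position, and it shows that a swap bringing in a six-membered aromatic ring of carbon only, an oxygen and a chlorine still leaves the two compounds impossible to tell apart on this read-out. Nothing available here explains this result.

From the compounds shown here alone, whether an amine or a carboxylic acid in this place would give a step beyond the scatter stays open. Going by these compounds, the part played by the chlorine also stays open, as a comparison with fluorine or a plain hydrogen on the same ring would be needed to test it, and compound 1 cannot settle either question, since it differs from compound 3 in more than one place.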